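The source may report more compounds than this note shows. Statements on the series, on what has been measured and on what is new or still open speak of the compounds shown alone.

Measured in a physicochemical assay for solubility, read by HPLC, with a stated time of 24 h; on this read-out higher numbers stand for higher solubility and lower numbers for lower solubility:
- Compound 1 `CC(C)(C)c1[nH]cnc1/C=c1\[nH]c(=O)/c(=C/c2cccc(C(=O)N3CCC3)c2)[nH]c1=O`: 4.23 ug/mL
- Compound 2 `CC(C)(C)c1[nH]cnc1/C=c1\[nH]c(=O)/c(=C/c2cccc(C(=O)c3ccsc3)c2)[nH]c1=O`: < 0.1 ug/mL (a limit, not a number)

Compound 2 stands at a limit of the assay: the limit of < 0.1 ug/mL in this assay, at which 1 of the 2 values shown sits.

Compound 3 `CC(C)(C)c1[nH]cnc1/C=c1\[nH]c(=O)/c(=C/c2cccc(C(=O)c3ccoc3)c2)[nH]c1=O` differs from compound 2 by furan-3-yl in place of thiophen-3-yl on a carbonyl carbon, with furan-3-yl in place of thiophen-3-yl on a carbonyl carbon. Among the compounds with values here, the only measured step, an at least 42-fold lower number from compound 1 to compound 2 (1.62 log units; beyond the scatter), is large, but it exchanges azetidin-1-yl for thiophen-3-yl, so it bears on this exchange only loosely. In this assay, little movement is therefore expected, perhaps slightly upward. The expected step is an at least 1.5-fold higher number from compound 2 to compound 3 (0.17 log units; that floor lies within the scatter). Compound 3 is estimated at 0.15 ug/mL, with an expected range of 0.05 ug/mL to 0.6 ug/mL.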

Compound 3, solubility: < 0.1 ug/mL
Compound 3 ended at the assay's limit (the forecaster's own chance of this, stated with the estimate: 45%); at least 1.5-fold (0.17 log units) between middle value and limit.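

In this assay, furan-3-yl on the carbonyl carbon gives an at least 42-fold lower number from compound 1 to compound 3 (1.62 log units; beyond the scatter), matching an at least 42-fold lower number from compound 1 to compound 2 (1.62 log units; beyond the scatter), so a second five-membered aromatic ring also falls far short of azetidin-1-yl. The exchange between thiophen-3-yl and furan-3-yl cannot be read, as compound 2 and compound 3 both stand at a limit and not at a number. Both ring compounds therefore sit at the floor of the read-out: the limit of < 0.1 ug/mL in this assay, at which 2 of the 3 values shown sit.

Open, on these data alone, is how morpholin-4-yl or dimethylamino on the carbonyl carbon would read in this assay. Also open, as far as these compounds go, is how far compound 2 and compound 3 lie beyond that limit.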